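Urea variants on the shared core: working notes

This account rests on a few compounds, and the source may have more. Where it says the series, first, only, none or still open, it means among the compounds named here.

Measured so far:
compound 1 `O=C(Nc1cccc(CNc2nccnc2Cl)c1)Nc1cccc2ccccc12`: in a functional assay on HepG2 cells (Homo sapiens) for antiproliferative activity, read by MTT assay, with a stated time of 48 h (a lower number here means a stronger inhibitor, a higher number a weaker inhibitor), compound 1 gives > 40000 nM, a limit of the assay.
compound 2 `O=C(Nc1cccc(CNc2nccnc2Cl)c1)NC1CCCCC1`: in this assay compound 2 gives > 40000 nM, also a limit.
compound 3 `CCc1ccc(NC(=O)Nc2cccc(CNc3nccnc3Cl)c2)c(CC)c1`: in this assay compound 3 gives 10800 nM.

Compound 2 therefore stands without a number of its own, at the limit of > 40000 nM in this assay, at which 2 of the 3 values shown sit. Within the data shown here, compound 3 is the only member of the set with a measured number. Among the measured compounds shown here, no two measured compounds differ in a single place, so no measured step is available to lean on.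

Compound 4 `CN(C)c1ccc(NC(=O)Nc2cccc(CNc3nccnc3Cl)c2)cc1` is the next candidate. Relative to compound 2 the change is 4-(dimethylamino)phenyl in place of cyclohexyl on an amide-type nitrogen.

What to expect: because compound 2 sits at the limit of > 40000 nM in this assay, at which 2 of the 3 values shown sit, the size of any step from it cannot be fixed from the data. Compound 3 shows that a measurable number is reachable in this set, while compound 1 shows that it is not guaranteed. For compound 4 the estimate in this assay is 20000 nM, with a range from 6000 nM to 40000 nM. The step from compound 2 to compound 4 is expected to be an at least 2.0-fold lower number from compound 2 to compound 4 (0.30 log units; that floor lies within the scatter), toward stronger inhibition if it is resolved at all, with a real chance that only a limit is returned again.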

Compound 4, half-maximal inhibitory concentration: > 40000 nM
Compound 4 gave a limit, no number; the forecaster's own chance of this, stated with the estimate: 45%; middle value at least 2.0-fold (0.30 log units) from the limit.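

In this assay compound 4 gives > 40000 nM, a limit of the assay. Compound 2 also stands at a limit, so no step between compound 2 and compound 4 can be read: the limit of > 40000 nM in this assay, at which 3 of the 4 values shown sit.

The compounds shown leave open whether 4-(dimethylamino)phenyl in place of cyclohexyl on an amide-type nitrogen changes the read-out at all, and by how much.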